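The source may report more compounds than this note shows. Statements on the series, on what has been measured and on what is new or still open speak of the compounds shown alone.

Measured so far:
compound 1 `CCn1ccc2cc(NC(=O)CN(c3cc(Cl)ccc3OC)S(=O)(=O)c3ccccc3)ccc21`: 2220 nM
compound 2 `COc1ccc(Cl)cc1N(CC(=O)Nc1cccc2ccccc12)S(=O)(=O)c1ccccc1`: 17400 nM

In a functional assay on SH-SY5Y cells (Homo sapiens), read by MTT assay, with a stated time of 24 h (a lower number here means that less compound is needed, a higher number that more compound is needed for the effect), compound 2 gives the higher of the two numbers, standing a 7.8-fold higher number from compound 1 to compound 2 (0.89 log units; beyond the scatter) away from compound 1. Compound 3 `COc1ccc(NC(=O)CN(c2cc(Cl)ccc2OC)S(=O)(=O)c2ccccc2)cc1OC` is not yet tested. The change is 3,4-dimethoxyphenyl in place of naphthalen-1-yl on an amide-type nitrogen. Going by the values given here, the only measured step at this position is a 7.8-fold higher number from compound 1 to compound 2 (0.89 log units; beyond the scatter), where one group replaced another on the same amide nitrogen; no step tests the incoming group itself, so the direction is open. Because compound 2 sits at 17400 nM at the top of the shown values, a move toward lower numbers is expected, a 2.2-fold lower number from compound 2 to compound 3 (0.34 log units; beyond the scatter). Compound 3 is estimated at 8000 nM, between 2000 nM and 30000 nM.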

Compound 3, half-maximal effective concentration: > 20000 nM
Compound 3: only a limit was reported; the forecaster's own chance of this, stated with the estimate: 15%; middle value at least 2.5-fold (0.39 log units) from the limit.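

In this assay, compound 3 gives only a limit and not a number: the limit of > 20000 nM in this assay, at which 1 of the 3 values shown sits.

Replacing the 1-ethyl-1H-indol-5-yl group on the amide-type nitrogen with 3,4-dimethoxyphenyl gives an at least 9.0-fold higher number from compound 1 to compound 3 (0.95 log units; beyond the scatter). Replacing naphthalen-1-yl with 3,4-dimethoxyphenyl gives an at least 1.1-fold higher number from compound 2 to compound 3 (0.06 log units; that floor lies within the scatter), so these two groups cannot be ranked, and of the three groups shown, only 1-ethyl-1H-indol-5-yl gives a clearly lower number.

Still open, as far as these compounds go, is whether a 1H-indol-5-yl group without the ethyl, or a phenyl ring carrying an amine or a carboxylic acid, would give a number as low as that of compound 1.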